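The source may report more compounds than this note shows. Statements on the series, on what has been measured and on what is new or still open speak of the compounds shown alone.

Measured compounds in a functional assay on SW-620 cells (Homo sapiens) for cytotoxicity, read by MTT assay, with a stated time of 72 h; on this read-out higher numbers stand for weaker inhibition and lower numbers for stronger inhibition:
- compound 1, `C#CCn1cc(C(=O)NC(CC(=O)Nc2ccccn2)c2ccccc2)c(=O)c2ccc(Cl)nc21`: 2900 nM
- compound 2, `C#CCn1cc(C(=O)NC(CC(=O)Nc2ccccc2)c2ccccc2)c(=O)c2ccc(Cl)nc21`: 2900 nM

Compound 2 stands level with compound 1 on the numbers shown; the only measured step, no change at the digits printed from compound 1 to compound 2 (within the scatter), stays within the scatter of the assay. Both compounds share the same core and differ only in the group carried on the outer amide-type nitrogen.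

Compound 3, `C#CCn1cc(C(=O)NC(CC(=O)NC2CCCC2)c2ccccc2)c(=O)c2ccc(Cl)nc21`, continues along that outer amide. The change is cyclopentyl in place of phenyl on an amide-type nitrogen. Among the measured compounds shown here, the one measured step bears on it only loosely: it shows that swapping one six-membered aromatic ring for another on that nitrogen left this assay unchanged, but it says nothing about replacing the aromatic ring with a non-aromatic five-membered ring of carbon only. For the measured compounds named here, with no measured step of that kind, the safest expectation is a step of about the size of a 1.0-fold higher number from compound 2 to compound 3 (0.01 log units; within the scatter), that is, nothing beyond the scatter, with the range widened to allow for the untested change. Compound 3 is therefore estimated at 3000 nM, expected to fall between 1200 nM and 8000 nM.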

Compound 3, half-maximal inhibitory concentration: 2700 nM
The estimate for compound 3 lay 1.1-fold (0.05 log units) above the measured number; low and high end bracket the measured number.
By their numbers in this assay, from the lowest: compounds 3, 1 and 2 (each within the scatter of the next).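

Putting cyclopentyl in place of phenyl on the amide-type nitrogen gives a 1.1-fold lower number from compound 2 to compound 3 (0.03 log units; within the scatter) in this assay, and putting it in place of pyridin-2-yl gives a 1.1-fold lower number from compound 1 to compound 3 (0.03 log units; within the scatter). Compound 1 and compound 2 carry six-membered aromatic rings at this position, whereas compound 3 carries a five-membered non-aromatic ring of carbon only, so this read-out does not separate the three groups, and an aromatic ring on this nitrogen is not required to stay at this level in these compounds. Nothing available explains why these three groups read alike.

Still open, going by these compounds, is whether this level would hold with a single methyl or an open butyl chain on that nitrogen, or with a ring carrying an amine or a carboxylic acid. The rest of the molecule stays fixed across all three compounds, so they give no indication of how the number would respond to a change elsewhere.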